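Swapping a Sulfone Arm for an Amide on the Shared Core

The source may report more compounds than this note shows. Statements on the series, on what has been measured and on what is new or still open speak of the compounds shown alone.

Three compounds have been measured in an assay on CHO cells for displacement of a labelled ligand from prostaglandin D2 receptor 2 (Homo sapiens), read by scintillation counting; on this read-out lower numbers stand for stronger inhibition and higher numbers for weaker inhibition:

Compound 1, `CS(=O)(=O)Cc1cccc(C#Cc2cc(Cl)ccc2OCC(=O)O)c1`: compound 1 gives 48 nM
Compound 2, `COCCN(C)S(=O)(=O)c1ccc(C)c(C#Cc2cc(Cl)ccc2OCC(=O)O)c1`: compound 2 gives 4.1 nM
Compound 3, `Cc1ccc(S(=O)(=O)Cc2ccccc2)cc1C#Cc1cc(Cl)ccc1OCC(=O)O`: compound 3 gives 5 nM

Compound 1 gives the highest number of the three, so it inhibits least strongly; its values against compound 3 and compound 2 show gaps well beyond the scatter. Among the measured compounds shown here, the only single-point change measured so far is a 1.2-fold higher number from compound 2 to compound 3 (0.09 log units; within the scatter), a change on a sulfonyl sulfur that tells little about what happens when the whole (methylsulfonyl)methyl group is exchanged.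

Compound 4, `CN(C)C(=O)c1cccc(C#Cc2cc(Cl)ccc2OCC(=O)O)c1`, differs from compound 1 in one place: dimethylcarbamoyl in place of (methylsulfonyl)methyl on an aromatic carbon. For the measured compounds named here, no measured step covers this kind of exchange, and nothing in the three values points to a clear direction. Compound 4 is therefore expected to give about 60 nM, most likely between 15 nM and 250 nM. The estimated step is a 1.3-fold higher number from compound 1 to compound 4 (0.10 log units; within the scatter), which is expected to fall within the scatter.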

Compound 4, inhibition constant: 52 nM
Estimate against measurement, compound 4: 1.2-fold (0.06 log units) above; the measured number falls inside the stated range.
By their numbers in this assay, from the lowest: compounds 2 and 3 (each within the scatter of the next); then compounds 1 and 4 (each within the scatter of the next).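

In this assay, the exchange gives a 1.1-fold higher number from compound 1 to compound 4 (0.03 log units; within the scatter), so on this aromatic carbon, meta to a large group, the sulfone-bearing arm can be replaced by an amide with no change that stands out from the scatter. The two groups share a count of 5 heavy atoms, and neither has a ring or a hydrogen-bond donor, yet they differ in their elements and in hydrogen-bond acceptors, and that difference leaves no readable mark here. Nothing on hand explains why the two groups read alike.

The compounds shown leave open whether an aminomethyl group, a carboxylic acid or a longer chain at this position would move the number. On these data alone, it is also open whether this exchange reads the same way on the core of compound 3, which carries an added methyl.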